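The source may hold more compounds than are shown below. What is called first, only, known or untested is meant among the compounds shown, and "the series" means these compounds.

Compound 1 `CCCC[C@@H](CCn1cncn1)c1ccccc1`: 47.5 ug/mL
Compound 2 `CCCC[C@@H](CCn1cncn1)c1ccc(F)cc1`: 34.1 ug/mL
Compound 3 `CCCC[C@@H](CCn1cncn1)c1ccc(C)cc1`: 56.5 ug/mL

These three compounds share one core and were read in an ADME assay on RD cells (Homo sapiens) for cytotoxicity, read by MTT assay, with a stated time of 3 days; a higher number here means that more compound is tolerated, a lower number that less compound is tolerated. On these numbers compound 1 sits among the other two without any gap beyond the scatter: a 1.2-fold higher number from compound 1 to compound 3 (0.08 log units; within the scatter), and a 1.4-fold lower number from compound 1 to compound 2 (0.14 log units; within the scatter). The remaining pair is no different: a 1.7-fold higher number from compound 2 to compound 3 (0.22 log units; within the scatter). All three compounds are therefore tolerated to about the same degree in this assay.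

Compound 4 `c1ccc(C[C@@H](CCn2cncn2)c2ccccc2)cc1` has not yet been measured. The change from compound 1 to compound 4 is phenyl in place of propyl on a saturated chain carbon, two bonds along the chain from an aromatic carbon. The three measured steps all concern a small group on the aromatic ring; none of them touches the saturated chain, so none bears directly on this change. What they do show is that every alteration tried so far on this core has left this assay unmoved, and each of those steps was within the scatter. Among the measured compounds shown here, with no direct precedent, the expectation for compound 4 rests on compound 1 and carries a wide range. Compound 4 is expected to give about 40 ug/mL, with a range from 18 ug/mL to 90 ug/mL. That estimate means an expected step of a 1.2-fold lower number from compound 1 to compound 4 (0.07 log units; within the scatter), not beyond the scatter.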

Compound 4, half-maximal cytotoxic concentration: 56 ug/mL
Compound 4: the middle estimate sits 1.4-fold (0.15 log units) below what was measured; the range from low to high includes it.
By their numbers in this assay, from the lowest: compounds 2, 1, 4 and 3 (each within the scatter of the next).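

Among the compounds shown here, until this result, every change to the shared core had been a small group on the aromatic ring, so this is the first reading of a change on the saturated chain. Replacing the open propyl chain with the larger phenyl ring, on a saturated chain carbon, two bonds along the chain from an aromatic carbon, gives a 1.2-fold higher number from compound 1 to compound 4 (0.07 log units; within the scatter) in this assay, so at this position, for this one pair, the swap from chain to ring shows no difference beyond the scatter. Nothing available here explains why these two groups give such similar readings.

Going by these compounds, it remains open whether this position would show the same lack of difference with a group of another kind, such as an amine or a carboxylic acid, or with a longer chain such as octyl. It is also open whether a fluoro or methyl group on the added phenyl would leave the reading just as close, since no group among these four compounds yet stands apart from the others beyond the scatter.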